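What one added hydroxy may do to compound 2

The source may report more compounds than this note shows. Statements on the series, on what has been measured and on what is new or still open speak of the compounds shown alone.

- Compound 1 `O=C(N/N=C/c1ccccc1O)c1ccc2ccccc2n1`: 56000 nM
- Compound 2 `O=C(N/N=C/c1cccc(O)c1O)c1ccnc2ccccc12`: 47500 nM
- Compound 3 `O=C(N/N=C/c1cc(O)ccc1O)c1ccnc2ccccc12`: > 650000 nM, a limit and not a number

All three values come from an ADME assay on U-937 cells (Homo sapiens) for cytotoxicity, read by MTT assay, with a stated time of 72 h; on this read-out lower numbers stand for higher toxicity in this test and higher numbers for lower toxicity in this test. There, compound 2 gives 47500 nM and compound 1 gives 56000 nM, and these two numbers lie within the usual scatter of each other. Compound 3 gives only a limit, > 650000 nM.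

The next compound to be tested is compound 4 `O=C(N/N=C/c1ccc(O)c(O)c1O)c1ccnc2ccccc12`. It differs from compound 2 in one place, with hydroxy in place of hydrogen on an aromatic carbon.

For the measured compounds named here, no measured pair of compounds shows this exact change, so the expectation is uncertain. The natural starting point is compound 2 at 47500 nM, and no step beyond the scatter is expected in this assay, in either direction. The estimated step is a 1.3-fold higher number from compound 2 to compound 4 (0.10 log units; within the scatter). The range stays wide on the upper side because compound 3 gives the limit > 650000 nM. For compound 4 the estimated value is 60000 nM, with an expected range from 15000 nM to 300000 nM.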

Compound 4, concentration lethal to 50% of the cells: 347000 nM
Beside the measured number, compound 4's estimate is 5.8-fold (0.76 log units) below it; the measured number lies above the stated range.
By their numbers in this assay, from the lowest: compounds 2 and 1 (each within the scatter of the next); then compound 4. At a limit, above all of these: compound 3.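

For the compounds shown here, until now, no pair of compounds showed what an added hydroxy does on this ring. In this assay, hydroxy in place of hydrogen on this aromatic carbon, ortho to a hydroxy group, meta to a hydroxy group and para to a large group, gives a 7.3-fold higher number from compound 2 to compound 4 (0.86 log units; beyond the scatter). A higher number here stands for lower toxicity in this test, so this one added oxygen atom moves the compound clearly toward lower toxicity to these cells, by a step beyond the scatter, and the scale has an upper end that any further rise would meet: the limit of > 650000 nM in this assay, at which 1 of the 4 values shown sits.

This single pair shows one group at one position, so it cannot tell whether the hydroxy itself matters or whether other groups on that carbon would give a similar step. A methoxy group, an amine or a fluorine at the same place would test this, and the same added hydroxy on compound 1 would show whether the step carries over to a different core.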